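A few compounds are considered here, and "the series" means these few. Any claim that something is new, unique, unknown or untested is made for them only; others in the source may bear on it.

Three compounds share one core and differ only in the side group on a saturated chain carbon bound to an amide-type nitrogen and a carbonyl carbon. In a functional assay on the whole organism with Mus musculus as the target, with a stated time of 90 min, at a dose of 25 umol/kg by the oral route (a lower number here means a weaker effect, a higher number a stronger effect of the compound at the dose given), compound 1 `C[C@H](NC(=O)CN(c1nc(Cl)nc2c1ncn2C1CCCCO1)C1CC1)C(=O)OCc1ccccc1` gives 32.1%, compound 2 `NC(=O)C[C@H](NC(=O)CN(c1nc(Cl)nc2c1ncn2C1CCCCO1)C1CC1)C(=O)OCc1ccccc1` gives 35%, and compound 3 `CC[C@H](C)[C@H](NC(=O)CN(c1nc(Cl)nc2c1ncn2C1CCCCO1)C1CC1)C(=O)OCc1ccccc1` gives 22.6%. Compound 3 stands at the low end of these numbers: a number 12.4 percentage points lower from compound 2 to compound 3 (beyond the scatter), while a number 9.5 percentage points lower from compound 1 to compound 3 (within the scatter), so compound 3 and compound 1 cannot be told apart with confidence.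

Compound 4 `CC(C)C[C@H](NC(=O)CN(c1nc(Cl)nc2c1ncn2C1CCCCO1)C1CC1)C(=O)OCc1ccccc1` differs from compound 3 at the same place: isobutyl in place of sec-butyl on a saturated chain carbon bound to an amide-type nitrogen and a carbonyl carbon. Among the compounds with values here, no measured step swaps one four-carbon chain for another; the two steps that bear on this position, a number 9.5 percentage points lower from compound 1 to compound 3 (within the scatter) and a number 12.4 percentage points lower from compound 2 to compound 3 (beyond the scatter), both change the size or the kind of group and were small to modest. Rearranging the same atoms is a smaller change than either, so no step beyond the scatter is expected, and the expected step is a number 4.4 percentage points higher from compound 3 to compound 4 (within the scatter). Compound 4 is therefore estimated to give 27% in this assay, with a likely range from 12% to 42%.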

Compound 4, a percentage reported as activity, at one dose (the size of the read-out at that dose, not a potency): 28.2%
Beside the measured number, compound 4's estimate is 1.2 percentage points below it, and the stated range covers the measured number.
By their numbers in this assay, from the lowest: compounds 3, 4, 1 and 2 (each within the scatter of the next, the first and the last beyond it).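

In this assay the swap of sec-butyl for isobutyl, which keeps the same four carbons but removes the defined stereocentre from the side group, amounts to a number 5.6 percentage points higher from compound 3 to compound 4 (within the scatter) and gives no readable change at this position. Within the data shown here, the isobutyl group also stays within the scatter of the two other side groups, with a number 3.9 percentage points lower from compound 1 to compound 4 (within the scatter) and a number 6.8 percentage points lower from compound 2 to compound 4 (within the scatter), so the one gap beyond the scatter among the earlier compounds, sec-butyl against carbamoylmethyl, does not recur with this four-carbon chain. Nothing measured here offers an explanation for these numbers.

Still open, on these data alone, is whether a side group carrying an amine or a carboxylic acid, or a longer chain such as hexyl, would move the read-out beyond the scatter. As far as these compounds go, each number gives only the size of the effect at a single dose, so whether one compound has a stronger or weaker effect than another at other doses also remains unknown.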